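The source may hold more compounds than are shown below. What is called first, only, known or untested is meant among the compounds shown, and "the series" means these compounds.

Series notes. Within the data shown here, compound 2 `ClCc1ccccc1Cn1cnc2ncnc(Cl)c21` stands second highest of the three numbers so far in a functional assay on M14 cells (Homo sapiens) for cytotoxicity, read by sulforhodamine B assay, with a stated time of 48 h (a lower number here means a stronger inhibitor of growth, a higher number a weaker inhibitor of growth), where compound 2 gives 1900 nM. Compound 1 `ClCc1cccc(Cn2cnc3c(Cl)nc(Cl)nc32)c1` gives 1770 nM in this assay, and the two values lie within the scatter of each other. Compound 3 `Nc1nc(Cl)c2ncn(Cc3cccc(CCl)c3)c2n1` gives 3630 nM, again within the scatter of compound 2. Among the measured compounds shown here, the only single-point step measured so far, a 2.1-fold higher number from compound 1 to compound 3 (0.31 log units; beyond the scatter), concerns an exchange at another site of the shared core and does not bear directly on the change now in question. Compound 4 `ClCc1ccccc1Cn1cnc2nc(Cl)nc(Cl)c21` differs from compound 2 by chloro in place of hydrogen on an aromatic carbon. Compound 1 carries this second chloro and compound 2 does not, but the two differ elsewhere in the structure as well, so their closeness in this assay is only an indirect hint. For the measured compounds named here, with no measured step bearing directly on the change, the expectation is a step of a 1.1-fold lower number from compound 2 to compound 4 (0.05 log units; within the scatter), not beyond the scatter. Compound 4 is estimated at 1700 nM in this assay, with a range from 700 nM to 4200 nM.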

Compound 4, concentration for 50% growth inhibition: 1860 nM
Compound 4: the middle estimate sits 1.1-fold (0.04 log units) below what was measured, within the range that was stated.
By their numbers in this assay, from the lowest: compounds 1, 4, 2 and 3 (each within the scatter of the next, the first and the last beyond it).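

In this assay, among these compounds, the step of a 1.0-fold lower number from compound 2 to compound 4 (0.01 log units; within the scatter) is the first direct reading of this change, and it lies within the scatter. On the core of compound 2, chloro in place of hydrogen on the aromatic carbon between two ring nitrogen atoms therefore leaves the growth-inhibition number unchanged within the scatter, where the closeness of compound 1 and compound 2 gave only an indirect hint. No measurement available here accounts for the size of this step.

On these data alone, whether a methoxy group, an amine or a longer chain on this carbon would also leave the number within the scatter of compound 2 and compound 4 remains open. As far as these compounds go, it also remains open whether the same exchange of hydrogen for chloro gives a similar step on the core of compound 1.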